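The source may report more compounds than this note shows. Statements on the series, on what has been measured and on what is new or still open speak of the compounds shown alone.

Measured so far in a toxicity assay (LMTK cells) for cytotoxicity, with Mus musculus as the target, read by MTT assay, with a stated time of 72 h; on this read-out lower numbers stand for stronger inhibition and higher numbers for weaker inhibition:
- compound 1 `Cc1c(C)c2c(c(C)c1OC(=O)CCC(=O)O)CCC(C)(C(=O)O)O2`: > 300000 nM
- compound 2 `Cc1c(C)c2c(c(C)c1OC(=O)CCC(=O)NCC1CC(C)(C)N([O])C1(C)C)CCC(C)(C(=O)NCC1CC(C)(C)N([O])C1(C)C)O2`: > 300000 nM
- compound 3 `Cc1c(C)c2c(c(C)c1OC(=O)CCC(=O)NCC1CC(C)(C)N([O])C1(C)C)CC[C@@](C)(CCC[C@H](C)CCC[C@H](C)CCCC(C)C)O2`: > 300000 nM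

Each entry is a limit of the assay and not a number. Compound 1 therefore has no numerical position in the series, and the whole set reads as the limit of > 300000 nM in this assay, at which 3 of the 3 values shown sit. No order among the three compounds can be drawn from these readings.

Compound 4 `Cc1c(C)c2c(c(C)c1OC(=O)CCC(=O)O)CCC(C)(C(=O)NC1CC(C)(C)N([O])C1(C)C)O2` keeps the core of compound 1 and differs in one place, on a carbonyl carbon whose other neighbours are a saturated ring carbon: a group of 11 heavy atoms (8 carbon, 2 nitrogen, 1 oxygen; one five-membered non-aromatic ring with 1 hetero atom) in place of one oxygen atom, on a carbonyl carbon. The hydroxy group leaves, and a group with one five-membered non-aromatic ring enters.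

Going by the values given here, no pair of measured compounds differs in one place only, so the size of this step cannot be read from a measured pair. No step beyond the scatter is expected in this assay, and no direction is favoured. This expectation rests on compound 1, which reads > 300000 nM, a limit. It also rests on compound 2, which reads > 300000 nM, a limit. Compound 3 reads > 300000 nM, also a limit, and gives the same support.

For compound 4 the estimate is 300000 nM, with an expected range of 120000 nM to 600000 nM. The estimated change is a number no higher from compound 1 to compound 4 (the limit leaves the size open), and a report at the limit is the expected outcome.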

Compound 4, half-maximal inhibitory concentration: > 300000 nM
Compound 4 ended at the assay's limit; the forecaster's own chance of this, stated with the estimate: 80%; the middle value lies on the limit itself.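

Compound 1 and compound 4 both read as limits in this assay, and no new step can be read from the pair: the limit of > 300000 nM in this assay, at which 4 of the 4 values shown sit. The compounds shown leave open whether any change on the shared core gives a numerical cytotoxicity reading here, and how these compounds would order against one another.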